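Cyclohexylmethyl for Tert-Butyl in a Cytotoxicity Series

The source may hold more compounds than are shown below. What is called first, only, known or untested is meant among the compounds shown, and "the series" means these compounds.

Three compounds share one core: compound 1 `C[C@H](NC(=O)c1cc(Cl)ccc1O)C(=O)Nc1ccc(C(F)(F)F)cc1`, compound 2 `C[C@H](NC(=O)c1ccc(Cl)cc1O)C(=O)Nc1ccc(Cl)c(Cl)c1` and compound 3 `CC(C)(C)[C@H](NC(=O)c1cc(Cl)ccc1O)C(=O)Nc1cccc(C(F)(F)F)c1`. In a functional assay on MCF7 cells (Homo sapiens) for cytotoxicity, with a stated time of 72 h (a lower number here means a stronger inhibitor, a higher number a weaker inhibitor), compound 1 reaches only the limit of > 12500 nM. In this assay compound 2 likewise reaches only the limit of > 12500 nM. Among the compounds with values here, compound 3 is the one member with a number: in this assay compound 3 gives 8800 nM, so it stands as the only measured value in the set. The other two sit at the limit of > 12500 nM in this assay, at which 2 of the 3 values shown sit. Within the data shown here, no step between measured compounds that differ in one place can be traced here.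

Compound 4 `O=C(N[C@@H](CC1CCCCC1)C(=O)Nc1cccc(C(F)(F)F)c1)c1cc(Cl)ccc1O` has not yet been measured. It differs from compound 3 by cyclohexylmethyl in place of tert-butyl on a saturated chain carbon bound to an amide-type nitrogen and a carbonyl carbon. Among the measured compounds shown here, since no measured pair shows what such an exchange does, no direction is set by the data. The step of a 1.5-fold lower number from compound 3 to compound 4 (0.17 log units; within the scatter) is expected to stay within the scatter, with a modest chance of a move toward a lower number. Compound 4 is therefore estimated at 6000 nM in this assay, between 1500 nM and 15000 nM.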

Compound 4, half-maximal inhibitory concentration: 2300 nM
Compound 4: the middle estimate sits 2.6-fold (0.42 log units) above what was measured, within the range that was stated.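

In this assay, cyclohexylmethyl in place of tert-butyl on a saturated chain carbon bound to an amide-type nitrogen and a carbonyl carbon gives a 3.8-fold lower number from compound 3 to compound 4 (0.58 log units; beyond the scatter). Within the data shown here, this is the first single change in the set that can be traced, and it shows that the number at this position responds to the group placed there. The entering group brings a six-membered non-aromatic ring of carbon only and more heavy atoms, yet the reading moves toward stronger inhibition, which the earlier compounds could not show, as two of the values are only a limit: the limit of > 12500 nM in this assay, at which 2 of the 4 values shown sit.

Whether the ring itself or simply the larger carbon group accounts for the step stays open, and an open n-hexyl chain or a benzyl group at this position would separate the two. As far as these compounds go, how an amine or a carboxylic acid on this carbon would read also remains open.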